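A new side chain on the most soluble compound

The compounds below may be only part of what the source reports. "The series", "measured", "known", "first", "only" and "open" are said of these compounds alone.

So far, three related compounds have been measured. In a physicochemical assay for solubility, read by HPLC, in phosphate buffer, at pH 6.5 (a lower number here means a less soluble compound, a higher number a more soluble compound), compound 1 (`COC(=O)C1=C(C)NC(c2nccs2)=N[C@]1(C)c1ccc(F)cc1`) gives 178 ug/mL and compound 2 (`COC(=O)C1=C(C)NC(c2nccs2)=NC1(C)c1ccc(Cl)cc1`) gives 14 ug/mL on the same scale. Compound 3 (`COC(=O)C1=C(CN2CCOCC2=O)NC(c2nccs2)=NC1(C)c1ccc(F)cc1`) stands highest of the three at 440 ug/mL with both others lower by more than the usual scatter of repeat measurements.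

Compound 4 (`COC(=O)C1=C(CN(C)C2(C(=O)O)CC2)NC(c2nccs2)=NC1(C)c1ccc(F)cc1`) has not been measured yet. It keeps the shared core and changes one group, on a saturated chain carbon bound to a double-bonded ring carbon (a group of 8 heavy atoms (5 carbon, 1 nitrogen, 2 oxygen; one three-membered non-aromatic ring of carbon only) in place of a group of 7 heavy atoms (4 carbon, 1 nitrogen, 2 oxygen; one six-membered non-aromatic ring with 2 hetero atoms), on a saturated chain carbon bound to a double-bonded ring carbon).

Among the measured compounds shown here, no measured pair differs in one place only, so nothing here gauges this swap directly, and any forecast is a judgement from the structures. The starting point is compound 3 at 440 ug/mL which is already the top of the range seen. A rise in this assay is still expected, with an estimated size of a 2.3-fold higher number from compound 3 to compound 4 (0.36 log units; beyond the scatter) and a good deal of uncertainty. For compound 4 the estimated solubility is 1000 ug/mL with between 300 ug/mL and 3000 ug/mL as its likely span.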

Compound 4, solubility: > 510 ug/mL
Compound 4 gave a limit, no number; the forecaster's own chance of this, stated with the estimate: 10%; the middle value is on the limit's open side.
By their numbers in this assay, from the lowest: compound 2; then compound 1; then compound 3. At a limit, above all of these: compound 4.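

Among the compounds shown here, this is the first change made in one place only: on a saturated chain carbon bound to a double-bonded ring carbon, the 3-oxomorpholin-4-yl group gives way to a group with a three-membered carbon ring and one hydrogen-bond donor. Read as a step in this assay, this is an at least 1.1-fold higher number from compound 3 to compound 4 (0.06 log units; that floor lies within the scatter), so the size of any real gain cannot be read from it. The place tolerates this larger, ring-changed group while the compound stays at the top of the series, a result that is a limit and not a number: the limit of > 510 ug/mL in this assay, at which 1 of the 4 values shown sits.

A plain amine without the carboxylic acid, or a longer chain in place of the three-membered ring, does not appear among the compounds shown, so which part of the new group goes with this result stays open. As far as these compounds go, how far compound 4 lies past its limit stays open too.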